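A few compounds are considered here, and "the series" means these few. Any claim that something is new, unique, unknown or untested is made for them only; others in the source may bear on it.

Compound 1 `O=S(=O)(c1ccccc1)n1ccc2cc(/C=C/c3ccc4ccccc4c3)ccc21`: > 5000 nM (a limit)
Compound 2 `O=S(=O)(c1ccccc1)n1ccc2cc(/C=C\c3ccc4ccccc4c3)ccc21`: > 5000 nM (a limit)
Not yet measured: compound 3 `Cn1ccc2cc(/C=C/c3ccc4ccccc4c3)ccc21`

In a functional assay on HCT-116 cells (Homo sapiens) for inhibition (a higher number here means a weaker inhibitor, a lower number a stronger inhibitor), compound 1 gives only a limit, > 5000 nM. Compound 2 also gives only a limit, > 5000 nM. Both values sit at the same ceiling: the limit of > 5000 nM in this assay, at which 2 of the 2 values shown sit.

The change to compound 3 is methyl in place of phenylsulfonyl on an aromatic nitrogen. Among the measured compounds shown here, the sole measured step is a step that the two limits leave unreadable from compound 1 to compound 2. For the measured compounds named here, it concerns (the fact that compounds 1 and 2 differ only in the configuration as drawn), so it has no bearing on the group on the nitrogen, and no measured step covers that change. Going by the values given here, the only anchor is compound 1, whose value of > 5000 nM is a limit.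

Any step in this assay is therefore weakly expected, and its direction is uncertain, with a modest leaning toward stronger inhibition. The expected step is an at least 1.2-fold lower number from compound 1 to compound 3 (0.09 log units; that floor lies within the scatter). For compound 3 the estimated value is 4000 nM, with an expected range from 600 nM to 15000 nM.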

Compound 3, half-maximal inhibitory concentration: > 5000 nM
Compound 3 gave a limit, no number; the forecaster's own chance of this, stated with the estimate: 55%; middle value at least 1.2-fold (0.09 log units) from the limit.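

Compound 3 gives only a limit, > 5000 nM, in this assay; compound 1 is also only a limit, so the step between them cannot be read. The compounds shown leave open how methyl and phenylsulfonyl on the aromatic nitrogen compare, and whether any of these compounds reaches a measurable value.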